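The source may hold more compounds than are shown below. What is called first, only, known or untested is meant among the compounds shown, and "the series" means these compounds.

In a functional assay on PC-3 cells (Homo sapiens) (on this read-out higher numbers stand for weaker inhibition of growth and lower numbers for stronger inhibition of growth), three compounds built on a shared core have been measured. Compound 1 `N#Cc1ccc(/C=C/S(=O)(=O)Cc2ccc(Nc3ncnc4ccccc34)cc2)cc1` returned only a limit, > 100000 nM. Compound 2 `O=S(=O)(/C=C/c1ccc(Cl)cc1)Cc1ccc(Nc2ncnc3ccccc23)cc1` gave 43000 nM. Compound 3 `O=S(=O)(/C=C/c1ccc(F)cc1Cl)Cc1ccc(Nc2ncnc3ccccc23)cc1` gave 100000 nM, the higher of the two actual numbers, with compound 2 as its nearest neighbour.

Compound 4 `O=S(=O)(/C=C/c1ccc(C(F)(F)F)cc1F)Cc1ccc(Nc2ncnc3ccccc23)cc1` differs from compound 3 on a double-bonded chain carbon bound to a double-bonded chain carbon: 2-fluoro-4-(trifluoromethyl)phenyl in place of 2-chloro-4-fluorophenyl on a double-bonded chain carbon bound to a double-bonded chain carbon. In words, 2-fluoro-4-(trifluoromethyl)phenyl takes the place of 2-chloro-4-fluorophenyl. Among the measured compounds shown here, no measured step makes this exchange, so the evidence is indirect. The closest guide is a 2.3-fold higher number from compound 2 to compound 3 (0.37 log units; beyond the scatter), a modest step that introduced the group compound 4 gives up. The step of an at least 2.3-fold lower number from compound 1 to compound 2 (0.36 log units; beyond the scatter) is also modest at the least, and shows that changing the aromatic substituent moved the number in this assay. The step of a number no higher from compound 1 to compound 3 (the limit leaves the size open) leaves its size open.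

With only modest steps among these close relatives, a small move toward a lower number is expected, and none beyond the scatter. The expected step is a 1.4-fold lower number from compound 3 to compound 4 (0.15 log units; within the scatter). A limit instead of a number remains possible for compound 4. For compound 4 the estimated value is 70000 nM, with an expected range from 25000 nM to 200000 nM.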

Compound 4, concentration for 50% growth inhibition: 100000 nM
Estimate against measurement, compound 4: 1.4-fold (0.15 log units) below; the range from low to high includes it.
By their numbers in this assay, from the lowest: compound 2; then compounds 3 and 4 (each within the scatter of the next).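

In this assay, putting 2-fluoro-4-(trifluoromethyl)phenyl in place of 2-chloro-4-fluorophenyl on a double-bonded chain carbon bound to a double-bonded chain carbon gave no change at the digits printed from compound 3 to compound 4 (within the scatter), with 11 heavy atoms in the entering group against 8 in the leaving one. Set against 4-chlorophenyl, the same group gave a 2.3-fold higher number from compound 2 to compound 4 (0.37 log units; beyond the scatter), which leaves compound 2 with the lowest number among the compounds shown, while a second aromatic substituent type, tried here with two different pairs of groups, has not matched it. How much the sameness of compound 3 and compound 4 says about the exchange is uncertain, because their numbers stand at the edge of what this read-out reports: the limit of > 100000 nM in this assay, at which 1 of the 4 values shown sits.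

Set against 4-cyanophenyl, the same group gave a number no higher from compound 1 to compound 4 (the limit leaves the size open), and the size of that step cannot be read, as the value it starts from is only a limit. As far as these compounds go, whether an amine or a carboxylic acid on this aromatic ring would bring the number lower than in compound 2 stays open, as does the effect of any change to the shared core.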